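This account rests on a few compounds, and the source may have more. Where it says the series, first, only, none or still open, it means among the compounds named here.

Working notes on the series. Among the measured compounds shown here, compound 3 `Cc1n[nH]c2ccc(-c3nc4cnc(N5CCN(C)CC5)cn4c3Nc3ccc(F)cc3Br)cc12` is the only member with a number in a functional assay on CWR22R cells (Homo sapiens) for inhibition, with a stated time of 120 h, tested at 10 uM; a lower number here means less inhibition, a higher number more inhibition at the concentration tested (going by the name of the read-out): compound 3 gives 4.41%. Compound 1 `Cc1n[nH]c2ccc(-c3nc4cnc(N5CCN(C)CC5)cn4c3Nc3ccccc3Cl)cc12` has no result in this assay, its entry being "not determined" (no result reported), and compound 2 `Cc1n[nH]c2ccc(-c3nc4cnc(N5CCN(C)CC5)cn4c3Nc3ccccc3)cc12` likewise stands at "not determined" (no result reported). For the measured compounds named here, with a single number, compound 3 can be placed nowhere relative to other members, and no step between measured compounds exists. Compound 4 `Cc1n[nH]c2ccc(-c3nc4cnc(N5CCN(C)CC5)cn4c3Nc3cc(Cl)ccc3Cl)cc12` is the next entry awaiting this assay. It differs from compound 3 by 2,5-dichlorophenyl in place of 2-bromo-4-fluorophenyl on a nitrogen on an aromatic ring. Going by the values given here, no measured step involves this kind of change, so no direction is expected beyond the scatter. The step from compound 3 to compound 4 is estimated as a number 2.6 percentage points higher from compound 3 to compound 4 (within the scatter). Compound 4 is expected to show 7%, within -8% to 22%.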

Compound 4, a percentage reported as inhibition, at one concentration (the size of the read-out at that concentration, not a potency): 3.8%
Estimate against measurement, compound 4: 3.2 percentage points above, and the stated range covers the measured number.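

In this assay, among the compounds shown here, 2,5-dichlorophenyl in place of 2-bromo-4-fluorophenyl on a nitrogen on an aromatic ring gives a number 0.6 percentage points lower from compound 3 to compound 4 (within the scatter), the first step that can be read at this position. This change of ring substituents therefore does not separate the two compounds in this read-out at the concentration tested. No available evidence bears on this result.

Steps involving compound 1 and compound 2 cannot be read. Still open, from the compounds shown here alone, is whether an amine or a carboxylic acid on this phenyl ring, or a longer chain in its place, would shift the read-out beyond the scatter.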